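Pyrrolyl in Place of Phenyl on a Kinase Inhibitor Core

This account rests on a few compounds, and the source may have more. Where it says the series, first, only, none or still open, it means among the compounds named here.

Measured in an assay on isolated protein for binding affinity to Leucine-rich repeat serine/threonine-protein kinase 2 (Homo sapiens), read by TR-FRET and LanthaScreen, with a stated time of 2 h; a higher number here means a weaker inhibitor, a lower number a stronger inhibitor:
Compound 1, `Cc1cn(C)nc1Nc1cc2c(c(N)n1)c(C#N)c(N1CCC[C@H]1C)n2C`, gives 63 nM.
Compound 2, `Cn1c(-c2ccccc2)c(C#N)c2c(N)ncnc21`, gives 30 nM.
Compound 3, `C[C@@H]1CCCN1c1c(C#N)c2c(N)nc(Nc3ccn(C)n3)cc2n1C`, gives 6 nM.

Among these three numbers compound 2 stands second highest. Its nearest neighbour is compound 1, whose number is higher, a gap beyond the scatter; furthest away is compound 3, whose number is lower, again beyond the scatter. Among the compounds with values here, the one step measured within one place, an 11-fold lower number from compound 1 to compound 3 (1.02 log units; beyond the scatter), is large, but it concerns a methyl on the shared core of those two compounds and not the group exchanged here.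

Compound 4, `Cn1c(-n2cccc2)c(C#N)c2c(N)ncnc21`, differs from compound 2 by 1H-pyrrol-1-yl in place of phenyl on an aromatic carbon. Within the data shown here, no measured step touches this exchange, so the data give no direction for it. The expected change is therefore a 1.2-fold higher number from compound 2 to compound 4 (0.07 log units; within the scatter), within the scatter. For compound 4 the estimate in this assay is 35 nM, with a likely range from 10 nM to 120 nM.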

Compound 4, inhibition constant: 239 nM
Estimate against measurement, compound 4: 6.8-fold (0.83 log units) below, and the stated range ends below it.
By their numbers in this assay, from the lowest: compound 3; then compound 2; then compound 1; then compound 4.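

In this assay, putting 1H-pyrrol-1-yl in place of phenyl on this aromatic carbon, next to the ring nitrogen, gives an 8.0-fold higher number from compound 2 to compound 4 (0.90 log units; beyond the scatter). The earlier compounds shown here held no step at this position, and this pair now shows that it is not indifferent to which aromatic ring it carries: here the five-membered ring with 1 hetero atom gives a weaker inhibitor than the six-membered ring of carbon only. No measurement at hand bears on why the two rings differ.

A single pair cannot separate the effect of ring size from that of the ring nitrogen. Going by these compounds, it also remains open how a pyridyl or thienyl ring, or a small amine, would fare on this carbon, and whether the same exchange would give a similar step on another core.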